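Swapping One Methyl for Fluorine on the Aryl Ring

The compounds below may be only part of what the source reports. "The series", "measured", "known", "first", "only" and "open" are said of these compounds alone.

Two compounds share a core and differ in the aryl group attached to it. Compound 1 `N#Cc1ccc(-c2ncnc3c2cnn3CCN2CCCCC2)cc1` gives 558 nM in an assay on HEK293 cells for displacement of a labelled ligand from Sigma non-opioid intracellular receptor 1 (Homo sapiens), read by scintillation counting, with a stated time of 120 min (on this read-out higher numbers stand for weaker inhibition and lower numbers for stronger inhibition), while compound 2 `Cc1ccc(C)c(-c2ncnc3c2cnn3CCN2CCCCC2)c1` gives 63 nM, the lowest of the two numbers; the step of an 8.9-fold lower number from compound 1 to compound 2 (0.95 log units; beyond the scatter). Compound 3 `Cc1cc(F)ccc1-c1ncnc2c1cnn2CCN1CCCCC1` carries the change (4-fluoro-2-methylphenyl in place of 2,5-dimethylphenyl on an aromatic carbon). Going by the values given here, no measured step covers this swap; the only step known concerns a different aryl exchange and was modest. A small step, if any, is therefore expected: a 1.5-fold higher number from compound 2 to compound 3 (0.18 log units; within the scatter). Compound 3 is estimated at 95 nM, within 35 nM to 250 nM.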

Compound 3, inhibition constant: 48 nM
The estimate for compound 3 lay 2.0-fold (0.30 log units) above the measured number, and the stated range covers the measured number.
By their numbers in this assay, from the lowest: compounds 3 and 2 (each within the scatter of the next); then compound 1.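

In this assay, the aryl groups of compound 2 and compound 3 cannot be told apart at this position: a 1.3-fold lower number from compound 2 to compound 3 (0.12 log units; within the scatter). Replacing 4-cyanophenyl with 4-fluoro-2-methylphenyl gives a 12-fold lower number from compound 1 to compound 3 (1.07 log units; beyond the scatter), so the low number of compound 2 is not tied to 2,5-dimethylphenyl alone. No measurement shown explains either step. As far as these compounds go, whether the methyl group shared by these two aryl groups is needed remains open. So does what a methoxy group or an amine on this aryl ring would do to the number.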